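The source may hold more compounds than are shown below. What is called first, only, known or untested is meant among the compounds shown, and "the series" means these compounds.

Of the compounds shown here, three that share one core have been measured in an ADME assay on microsomes from liver (Rattus norvegicus) for metabolic stability, read by LC-MS, using NADPH, at 37 degrees C; a lower number here means that the compound disappears faster, a higher number that the compound lasts longer: compound 1 (`Cc1ccc(C)c(-c2nc(CN3CCC(C(=O)NCCCN4C[C@H](C)C[C@H](C)C4)CC3)c(C)o2)c1`), compound 2 (`Cc1oc(-c2ccc(Cl)cc2)nc1CN1CCC(C(=O)NCCCN2C[C@H](C)C[C@H](C)C2)CC1`) and compound 3 (`Cc1oc(-c2ccc(F)cc2)nc1CN1CCC(C(=O)NCCCN2C[C@H](C)C[C@H](C)C2)CC1`). Compound 1 gives 0.5 h as its half-life. Compound 2 gives > 0.5 h, which is a limit and not a number. Compound 3 gives 0.468 h and so stands within the scatter of compound 1. As a step, that gap reads a 1.1-fold lower number from compound 1 to compound 3 (0.03 log units; within the scatter) and shows no real difference.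

Compound 4 (`Cc1oc(-c2ccc(Cl)c(Cl)c2)nc1CN1CCC(C(=O)NCCCN2C[C@H](C)C[C@H](C)C2)CC1`) differs from compound 3 by one group, with 3,4-dichlorophenyl in place of 4-fluorophenyl on an aromatic carbon is the full count.

Two further measured steps bear on this change. The step of an at least 1.0-fold lower number from compound 2 to compound 3 (0.02 log units; that floor lies within the scatter) swaps fluoro for chloro, yet it only sets a floor, and that floor lies within the scatter. The step of a number no lower from compound 1 to compound 2 (the limit leaves the size open) has no readable size. The only exact step among these compounds, a 1.1-fold lower number from compound 1 to compound 3 (0.03 log units; within the scatter) again, therefore suggests no change beyond the scatter in this assay, though this is thin evidence. With compound 2 at > 0.5 h as a limit, compound 4 may also be reported only as a limit.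

The expected change is a 1.1-fold higher number from compound 3 to compound 4 (0.03 log units; within the scatter) and stays within the scatter. For compound 4 the estimated half-life is 0.5 h with an expected range from 0.25 h to 1 h in this measurement.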

Compound 4, half-life: > 0.5 h
Compound 4: no number, only a limit; the forecaster's own chance of this, stated with the estimate: 35%; the middle value lies on the limit itself.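

In this assay compound 4 gives > 0.5 h, which is a limit and not a number, so putting 3,4-dichlorophenyl in place of 2,5-dimethylphenyl gives a number no lower from compound 1 to compound 4 (the limit leaves the size open). Putting 3,4-dichlorophenyl in place of 4-fluorophenyl gives an at least 1.0-fold higher number from compound 3 to compound 4 (0.02 log units; that floor lies within the scatter), so the data show no shorter half-life for the dichlorinated compound, yet they cannot tell whether it lasts any longer in a real sense. The step to compound 4 from compound 2 cannot be read, and the true size of any gain remains hidden because the measurements stop at a limit: the limit of > 0.5 h in this assay, at which 2 of the 4 values shown sit.

As far as these compounds go, without exact half-lives for the two chlorinated compounds, it remains open whether the added chloro changes the half-life at all, or whether chloro and fluoro differ in this assay. The compounds shown also leave open how the half-life would respond to a phenyl ring bearing a methoxy group or a nitrile, or to an amine in place of the phenyl ring at this position.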